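Series notes: from compound 2 to compound 3

The compounds below may be only part of what the source reports. "The series", "measured", "known", "first", "only" and "open" are said of these compounds alone.

Two members of the series have been measured in an assay on CHO cells for displacement of a labelled ligand from adenosine receptor A3 (Homo sapiens), read by scintillation counting, tested at 10 uM; on this read-out higher numbers stand for more inhibition at the one concentration tested (going by the name of the read-out) and lower numbers for less inhibition. Compound 1 `CC(C)(C)Cc1csc(N)c1C(=O)c1cccc(Cl)c1` gives 8% in this assay. Compound 2 `CC(C)(C)Cc1c(-c2ccoc2)sc(N)c1C(=O)c1ccc(Cl)cc1` gives 1% in this assay, a number that lies within the usual scatter of the value of compound 1, so the two cannot be separated on these data; both sit close to the bottom of the scale.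

Compound 3 `CC(C)(C)Cc1c(/C=C/c2ccc(Cl)cc2)sc(N)c1C(=O)c1ccc(Cl)cc1` has not been measured. It differs from compound 2 in one place: 2-(4-chlorophenyl)ethenyl in place of furan-3-yl on an aromatic carbon. Going by the values given here, no measured pair shows the effect of such a change, so nothing in the data points to a large move in either direction. The step from compound 2 to compound 3 is expected to be small, a number 9 percentage points higher from compound 2 to compound 3 (within the scatter), upward if anything and possibly not beyond the scatter. Compound 3 is therefore estimated at 10%, with a range from 0% to 35%.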

Compound 3, a percentage reported as inhibition, at one concentration (the size of the read-out at that concentration, not a potency): 11%
For compound 3 the middle estimate is 1 percentage points below the measured one; the range from low to high includes it.
By their numbers in this assay, from the lowest: compounds 2, 1 and 3 (each within the scatter of the next).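

In this assay, going by these compounds alone, replacing furan-3-yl with 2-(4-chlorophenyl)ethenyl on the aromatic carbon next to the ring sulfur gives a number 10 percentage points higher from compound 2 to compound 3 (within the scatter), the first step that can be read at this position. A group of 9 heavy atoms, with a double bond outside the aromatic ring and a chlorine, therefore stands here in place of one of 5 heavy atoms with no move beyond the scatter, and both compounds stay near the bottom of the scale. No measured finding is available to account for this result.

As far as these compounds go, whether an amine, a carboxylic acid or a plain alkyl chain at this position would give a step beyond the scatter remains open. So does whether a longer chain in place of the neopentyl group would change the read-out.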